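Ester chain trimmed: notes on compounds 2 and 3

This account rests on a few compounds, and the source may have more. Where it says the series, first, only, none or still open, it means among the compounds named here.

compound 1 `c1ccc(Cn2cncc2CNc2cccc(-c3ccccc3)c2)cc1`: > 750 nM
compound 2 `CC(C)OC(=O)c1ccc(NCc2cncn2Cc2ccc(-c3ccccc3)cc2)cc1-c1ccccc1`: > 10000 nM

In a toxicity assay on NIH3T3 cells (Mus musculus) for cytotoxicity, read by resazurin assay (a lower number here means that less compound is needed, a higher number that more compound is needed for the effect), compound 1 gives > 750 nM, which is a limit of the assay and not a number. Compound 2 gives > 10000 nM, again only a limit; compound 2 therefore sits at the limit of > 10000 nM in this assay, at which 1 of the 2 values shown sits, with no measured number behind it. Going by the values given here, no two measured compounds differ in a single place, so no measured step exists. Compound 3 `CCOC(=O)c1ccc(NCc2cncn2Cc2ccc(-c3ccccc3)cc2)cc1-c1ccccc1` differs from compound 2 by hydrogen in place of methyl on a saturated chain carbon bound to an oxygen next to a carbonyl group and a saturated chain carbon. The expected step is a step that the limit leaves unreadable from compound 2 to compound 3, nothing beyond the scatter. Compound 3 is estimated at 15000 nM, range 5000 nM to 50000 nM, most likely reported again as a limit.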

Compound 3, half-maximal effective concentration: > 10000 nM
Compound 3 was reported as a limit; the forecaster's own chance of this, stated with the estimate: 80%; the middle value lies beyond the limit too.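

Compound 2 and compound 3 both stop at a limit of the assay, so the step between them cannot be read. On these data alone, whether isopropoxycarbonyl to ethoxycarbonyl changes cytotoxicity at all, and by how much, stays open.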